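This account rests on a few compounds, and the source may have more. Where it says the series, first, only, none or still open, it means among the compounds named here.

Of the compounds shown here, three sharing one core have been measured in a functional assay on MGC-803 cells (Homo sapiens) for antiproliferative activity, read by CCK-8 assay, with a stated time of 72 h, tested at 8 uM; on this read-out higher numbers stand for a stronger effect at the one concentration tested and lower numbers for a weaker effect. Compound 1 `Nc1ccccc1NC(=O)c1ccc(CSC(=S)N2CCN(c3ccncc3)CC2)cc1` gives 87.1%. Compound 2 `Nc1ccccc1NC(=O)c1ccc(CSC(=S)N2CCN(Cc3ccccc3)CC2)cc1` gives 19.7%. Compound 3 `Nc1ccccc1NC(=O)c1ccc(CSC(=S)N2CCN(c3ccccc3F)CC2)cc1` gives 86.4%. On these numbers compound 3 stands second highest of the three: its value and that of compound 1 lie within the scatter of each other, while compound 2 lies far below it.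

The steps between these compounds tell a simple story. The drop of a number 67.4 percentage points lower from compound 1 to compound 2 (beyond the scatter) is large. The change of a number 0.7 percentage points lower from compound 1 to compound 3 (within the scatter) is within the scatter. The rise of a number 66.7 percentage points higher from compound 2 to compound 3 (beyond the scatter) is large again.

Compound 4 `Nc1ccccc1NC(=O)c1ccc(CSC(=S)N2CCN(c3ncccn3)CC2)cc1` differs from compound 3 in one place: pyrimidin-2-yl in place of 2-fluorophenyl on an amine nitrogen in a ring

For the measured compounds named here, the step that bears most directly on this change is the one from compound 1 to compound 3, where one six-membered aromatic ring on the amine nitrogen replaced another and the number hardly moved. The large step from compound 1 to compound 2 involved benzyl, a different kind of group, and so says less here. A step of a number 6.4 percentage points lower from compound 3 to compound 4 (within the scatter) is therefore expected, which is none beyond the scatter. In this assay compound 4 is estimated to give 80%, within a range from 60% to 92%.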

Compound 4, a percentage reported as inhibition, at one concentration (the size of the read-out at that concentration, not a potency): 64.8%
For compound 4 the middle estimate is 15.2 percentage points above the measured one; measured number inside the range.
By their numbers in this assay, from the lowest: compound 2; then compound 4; then compounds 3 and 1 (each within the scatter of the next).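

Until now, the two aromatic rings on this amine nitrogen, pyridin-4-yl and 2-fluorophenyl, had read alike in this assay, which left room to think that any six-membered aromatic ring would serve here, but pyrimidin-2-yl breaks that picture, with a number 21.6 percentage points lower from compound 3 to compound 4 (beyond the scatter) and a number 22.3 percentage points lower from compound 1 to compound 4 (beyond the scatter) as the ring changes. The position is therefore more selective than the first three compounds suggested, yet the new ring still holds much of the effect that benzyl loses, as a number 45.1 percentage points higher from compound 2 to compound 4 (beyond the scatter) shows, so that these compounds now fall into three levels: benzyl lowest, pyrimidin-2-yl in the middle, and pyridin-4-yl and 2-fluorophenyl together at the top. Nothing measured here explains why pyrimidin-2-yl falls short of the other two rings.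

The compounds shown leave open whether a plain phenyl or a pyridin-2-yl ring on this nitrogen would read with the top pair or with compound 4. They also leave open how a non-aromatic group such as methyl or acetyl would fare here, and every reading comes from a single concentration, so none of them gives a potency.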